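Replacing 3-methoxyphenyl with thiophen-2-yl in compound 2

The source may hold more compounds than are shown below. What is called first, only, known or untested is meant among the compounds shown, and "the series" means these compounds.

In a functional assay on COLO 205 cells (Homo sapiens) for inhibition, read by sulforhodamine B assay, with a stated time of 48 h, tested at 50 uM (on this read-out lower numbers stand for less inhibition of growth and higher numbers for more inhibition of growth at the one concentration tested), compound 1 (`COc1cccc(/C=C/C(=O)/C=C/c2ccc(OCc3cn(CCCCCOc4cc(=O)oc5ccccc45)nn3)c(OC)c2)c1`) gives 34% while compound 2 (`COc1cccc(/C=C/C(=O)/C=C/c2ccc(OCc3cn(CCCCOc4cc(=O)oc5ccccc45)nn3)c(OC)c2)c1`) gives 46% as the higher of these two numbers, a gap beyond the scatter. Compound 3 (`COc1cc(/C=C/C(=O)/C=C/c2cccs2)ccc1OCc1cn(CCCCOc2cc(=O)oc3ccccc23)nn1`) has thiophen-2-yl in place of 3-methoxyphenyl on a double-bonded chain carbon bound to a double-bonded chain carbon. Among the compounds with values here, no measured pair of compounds shows this swap, so the estimated step (a number 2 percentage points lower from compound 2 to compound 3 (within the scatter)) is expected to stay within the scatter, with no firm direction. The expected value for compound 3 is 44% within an estimated range of 28% to 60% for repeated measurements.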

Compound 3, percent growth inhibition at one concentration: 40%
Compound 3: the middle estimate sits 4 percentage points above what was measured; the measured number falls inside the stated range.
By their numbers in this assay, from the lowest: compounds 1, 3 and 2 (each within the scatter of the next, the first and the last beyond it).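

In this assay, the step of a number 6 percentage points lower from compound 2 to compound 3 (within the scatter) shows that this position, on a double-bonded chain carbon bound to a double-bonded chain carbon, tolerates thiophen-2-yl in place of 3-methoxyphenyl. A five-membered aromatic ring with one sulfur can therefore stand in for the six-membered carbon ring without a difference that this read-out can separate from scatter. Nothing available here explains this result. Still open, on these data alone, is whether a group carrying an amine or a carboxylic acid would fit this position equally well. Also open, as far as these compounds go, is whether the same swap would give a similar step on the chain of compound 1.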